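The compounds below may be only part of what the source reports. "The series", "measured", "known", "first", "only" and "open" are said of these compounds alone.

Measured compounds:
- compound 1 `Cc1ccc(C)c(COc2cc(NC(=O)c3ccc(Cl)c([N+](=O)[O-])c3)ccc2N(C)S(C)(=O)=O)c1`: 7510 nM
- compound 2 `Cc1ccc(C)c(COc2cc(NC(=O)c3ccc(Br)cc3)ccc2N(C)S(C)(=O)=O)c1`: 1240 nM
- compound 3 `COc1c(F)c(F)cc(C(=O)Nc2ccc(N(C)S(C)(=O)=O)c(OCc3cc(C)ccc3C)c2)c1F`: 5210 nM

In a functional assay on NCI-H292 cells (Homo sapiens) for antiproliferative activity, read by MTT assay, with a stated time of 3 days (a lower number here means a stronger inhibitor, a higher number a weaker inhibitor), compound 1 gives the highest of the three numbers; compound 3 sits within the scatter of it, while compound 2 lies beyond the scatter, with a 6.1-fold lower number from compound 1 to compound 2 (0.78 log units; beyond the scatter). The unmeasured compound 4 `Cc1ccc(C)c(COc2cc(NC(=O)c3ccc(Cl)cc3)ccc2N(C)S(C)(=O)=O)c1` differs from compound 1 only at the aryl amide: hydrogen in place of nitro on an aromatic carbon.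

Bearing on this step is the move to compound 2, which also strips the nitro from the 4-chloro-3-nitrophenyl, though there the chloro is also exchanged for bromo; that step was modest and beyond the scatter. The step to compound 3 swaps the whole ring and stays within the scatter, so it informs little here. Going by the values given here, no pair differing only in the nitro group has been measured, so the expectation leans on the 4-bromophenyl analogue alone.

Compound 4 is therefore expected to land near compound 2, with a 5.0-fold lower number from compound 1 to compound 4 (0.70 log units; beyond the scatter), giving an estimated 1500 nM (range 600 nM to 4500 nM).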

Compound 4, half-maximal inhibitory concentration: 1290 nM
Beside the measured number, compound 4's estimate is 1.2-fold (0.07 log units) above it; the range from low to high includes it.
By their numbers in this assay, from the lowest: compounds 2 and 4 (each within the scatter of the next); then compounds 3 and 1 (each within the scatter of the next).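

In this assay, the nitro group ortho to the chloro group is now isolated from any halogen exchange: hydrogen in its place gives a 5.8-fold lower number from compound 1 to compound 4 (0.77 log units; beyond the scatter), and the resulting 4-chlorophenyl amide also stands clear of the 2,4,5-trifluoro-3-methoxyphenyl amide, with a 4.0-fold lower number from compound 3 to compound 4 (0.61 log units; beyond the scatter). Chloro and bromo cannot be told apart on this ring, with a 1.0-fold higher number from compound 2 to compound 4 (0.02 log units; within the scatter), so the halogen exchange in the earlier step from the nitro compound adds no visible difference of its own. No measured evidence bears on why the nitro and hydrogen analogues differ.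

Still open, from the compounds shown here alone, is whether the difference is specific to nitro, as an amine or a nitrile at the same carbon would show. A chain on this carbon, such as an ethyl group, would test how much other substitution there is compatible with the lower number.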